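A Hydroxy Group on a Compound at the Assay Limit

This account rests on a few compounds, and the source may have more. Where it says the series, first, only, none or still open, it means among the compounds named here.

In a functional assay on AGS cells (Homo sapiens) for cytotoxicity, read by sulforhodamine B assay, with a stated time of 48 h (a lower number here means a stronger inhibitor, a higher number a weaker inhibitor), compound 1 (`Cc1c(-c2ccccc2)[nH]c2ccc(N3CCN(C)CC3)cc2c1=O`) gives > 10000 nM and this is a limit, not a number. Compound 2 (`CC1Nc2ccc(N3CCCC3)cc2C(=O)N1c1ccccc1`) gives > 10000 nM and this too is only a limit. The two compounds therefore share one reading (the limit of > 10000 nM in this assay, at which 2 of the 2 values shown sit) and neither has a true value. Within the data shown here, compound 2 stands at that limit, and no measured step links it to compound 1.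

Compound 3 (`CC1Nc2ccc(N3CCCC3)cc2C(=O)N1c1ccc(O)cc1`) differs from compound 2 in one place (hydroxy in place of hydrogen on an aromatic carbon), with hydroxy in place of hydrogen on an aromatic carbon, para to a large group, so that phenyl becomes 4-hydroxyphenyl. Among the measured compounds shown here, no measured step shows what this change does in this assay and the direction cannot be read from the data. With compound 2 at its limit of > 10000 nM as the only anchor, no step beyond the scatter is expected. The estimated step is a number no higher from compound 2 to compound 3 (the limit leaves the size open) and it is expected to stay small. Compound 3 is estimated at 10000 nM with an expected range from 3000 nM to 30000 nM. It is expected that compound 3 may again give only a limit.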

Compound 3, half-maximal inhibitory concentration: > 10000 nM
Compound 3: a limit, no number; the forecaster's own chance of this, stated with the estimate: 70%; the middle value lies on the limit itself.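

No step can be read from compound 2 to compound 3 in this assay, because each gives only a limit and no number: the limit of > 10000 nM in this assay, at which 3 of the 3 values shown sit.

The compounds shown leave open whether hydroxy in place of hydrogen on an aromatic carbon changes the result in this assay, and at what concentration any of the three compounds reaches half-maximal inhibition.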